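Pyrrolidine in place of propylamino on the nitro-trifluoromethyl core

This account rests on a few compounds, and the source may have more. Where it says the series, first, only, none or still open, it means among the compounds named here.

Measured compounds:
compound 1: `CC1CCN(c2nc(=O)c3cc([N+](=O)[O-])cc([N+](=O)[O-])c3s2)CC1` — "not determined" (no result reported) in an ADME assay on Vero cells (Chlorocebus sabaeus) for cytotoxicity, read by MTT assay, with a stated time of 72 h; on this read-out higher numbers stand for weaker inhibition and lower numbers for stronger inhibition
compound 2: `CCCNc1nc(=O)c2cc(C(F)(F)F)cc([N+](=O)[O-])c2s1` — > 100000 nM in this assay

For compound 1 the result in this assay is "not determined" (no result reported), so no number is available for it. Compound 2 gives only a limit in this assay, > 100000 nM, which is the boundary of the measurement and not a measured number; it sits at the limit of > 100000 nM in this assay, at which 1 of the 2 values shown sits. For the measured compounds named here, with one entry at the limit and one without a result, no step between measured compounds can be drawn, and compound 2 simply stands at the weakest end that the assay reports.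

Compound 3, `O=c1nc(N2CCCC2)sc2c([N+](=O)[O-])cc(C(F)(F)F)cc12`, is not yet measured. It differs from compound 2 in one place: pyrrolidin-1-yl in place of propylamino on an aromatic carbon. The change from compound 2 to compound 3 is expected to give no step beyond the usual scatter in this assay, that is a number no higher from compound 2 to compound 3 (the limit leaves the size open). Compound 3 is therefore estimated at 100000 nM in this assay, within a range from 30000 nM to 300000 nM, most likely again reported only as a limit.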

Compound 3, half-maximal inhibitory concentration: > 100000 nM
Compound 3: no number, only a limit; the forecaster's own chance of this, stated with the estimate: 75%; the middle value sits exactly at the limit.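

In this assay compound 3 gives > 100000 nM, which is a limit and not a number. Compound 2 also gives only a limit, so no step can be read between compound 2 and compound 3: the limit of > 100000 nM in this assay, at which 2 of the 3 values shown sit.

The compounds shown leave open whether pyrrolidin-1-yl in place of propylamino changes this read-out at all.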